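A few compounds are considered here, and "the series" means these few. Any claim that something is new, unique, unknown or untested is made for them only; others in the source may bear on it.

Going by the values given here, in a functional assay on HL-60 cells (Homo sapiens) for antiproliferative activity, read by MTT assay, with a stated time of 72 h (a lower number here means a stronger inhibitor, a higher number a weaker inhibitor), compound 1 `NC1=NC2(CCSCC2)N(OCCCOc2ccc(Cl)c(Cl)c2)C(N)=N1` gives 140 nM, the lowest of the three numbers measured so far, while compound 2 `NC1=NC2(CCOCC2)N(OCCCOc2ccc(Cl)cc2)C(N)=N1` gives 330 nM and compound 3 `NC1=NC2(CCOCC2)N(OCCCOc2ccc(Cl)cc2Cl)C(N)=N1` gives 330 nM. Compound 4 `NC1=NC2(CCSCC2)N(OCCCOc2ccccc2Cl)C(N)=N1` has not yet been measured. It keeps the core of compound 1 and differs from it as follows: 2-chlorophenyl in place of 3,4-dichlorophenyl on an oxygen on a saturated carbon. Among the compounds with values here, only one measured step concerns chlorine on the aromatic ring, and it shows no change at the digits printed from compound 2 to compound 3 (within the scatter). That step bears only in part, since it adds a chloro on the core of compound 2, whereas the present change leaves one chlorine fewer on the core of compound 1. Within the data shown here, no measured pair tests 2-chlorophenyl or 3,4-dichlorophenyl directly. A small step in this assay is therefore expected, toward a higher number if it exceeds the scatter at all. The estimated step is a 1.4-fold higher number from compound 1 to compound 4 (0.15 log units; within the scatter). For compound 4 the expected value is 200 nM, with an estimated range from 80 nM to 500 nM.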

Compound 4, half-maximal inhibitory concentration: 390 nM
For compound 4 the middle estimate is 2.0-fold (0.29 log units) below the measured one; measured number inside the range.
By their numbers in this assay, from the lowest: compound 1; then compounds 2, 3 and 4 (each within the scatter of the next).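

Exchanging 3,4-dichlorophenyl for 2-chlorophenyl on an oxygen on a saturated carbon gives, in this assay, a 2.8-fold higher number from compound 1 to compound 4 (0.44 log units; beyond the scatter), so a change in the chlorines on this aromatic ring can move the number beyond the scatter. The earlier chlorine step, showing no change at the digits printed from compound 2 to compound 3 (within the scatter), did not, but it added a chloro on a different core, so the two steps cannot be set side by side as a single trend. Nothing available accounts for the size or direction of the new step.

This step removes one chlorine and alters the chlorine pattern at once, so the compounds shown cannot separate the two, and 3-chlorophenyl or 4-chlorophenyl on the core of compound 1 would bear on that. Also open, as far as these compounds go, is how a methoxy or trifluoromethyl group on the ring, or a longer chain to the oxygen, would read here.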